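Taking the 4-butylcyclohexyl group off compound 2

The compounds below may be only part of what the source reports. "The series", "measured", "known", "first", "only" and "open" are said of these compounds alone.

Measured in an ADME assay on Vero 76 cells (Chlorocebus sabaeus) for cytotoxicity, read by crystal violet staining, with a stated time of 96 h; on this read-out higher numbers stand for lower toxicity in this test and lower numbers for higher toxicity in this test
compound 1 `FC(F)(F)c1cccc(NC(=S)Nc2ccc(Cl)cc2)c1` gives 11000 nM
compound 2 `CCCC[C@H]1CC[C@H](c2ccc(NC(=S)Nc3cccc(C(F)(F)F)c3)cc2)CC1` gives 17000 nM
compound 3 `CCCCc1ccc(NC(=S)Nc2cccc(C(F)(F)F)c2)c(C)c1` gives 18000 nM

Compound 2, at 17000 nM, lies within the scatter of both compound 1 and compound 3. The next compound, compound 4 `FC(F)(F)c1cccc(NC(=S)Nc2ccccc2)c1`, has not yet been measured. Its change from compound 2 is hydrogen in place of 4-butylcyclohexyl on an aromatic carbon, which puts hydrogen in place of 4-butylcyclohexyl on an aromatic carbon. Among the compounds with values here, only one measured step involves this group: a 1.5-fold higher number from compound 1 to compound 2 (0.19 log units; within the scatter). Within the data shown here, that step stays within the scatter, but no measured compound carries hydrogen at this place, so it is indirect evidence. In this assay, no step beyond the scatter is therefore expected. The expected step is a 1.2-fold lower number from compound 2 to compound 4 (0.08 log units; within the scatter). For compound 4 the estimate is 14000 nM, with an expected range from 6500 nM to 30000 nM.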

Compound 4, half-maximal cytotoxic concentration: 39000 nM
Compound 4: middle estimate off by 2.8-fold (0.44 log units), on the low side, and the stated range ends below it.
By their numbers in this assay, from the lowest: compounds 1, 2 and 3 (each within the scatter of the next); then compound 4.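

In this assay hydrogen on this aromatic carbon gives a 2.3-fold higher number from compound 2 to compound 4 (0.36 log units; beyond the scatter) and also a 3.5-fold higher number from compound 1 to compound 4 (0.55 log units; beyond the scatter) so either group at this place goes with a lower number than hydrogen does. Compound 1 and compound 2 lie within the scatter of each other, so among these three compounds, having a group here counts for more than which of these two it is. Nothing measured here explains this result.

As far as these compounds go, it remains open whether a methyl group, a methoxy group or an amine at this place would give a number nearer compound 4 or nearer compound 1. From the compounds shown here alone, whether the same holds with the trifluoromethyl group replaced also remains open.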